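This account rests on a few compounds, and the source may have more. Where it says the series, first, only, none or still open, it means among the compounds named here.

Among the measured compounds shown here, compound 2, `O=C(Nc1ccccc1[N+](=O)[O-])c1ccc(/N=N\c2c[nH]c3ccccc23)cc1`, gives 101000 nM in a functional assay on MCF7 cells (Homo sapiens) for inhibition, read by MTT assay, with a stated time of 72 h (a lower number here means a stronger inhibitor, a higher number a weaker inhibitor), the lower of the two numbers so far; compound 1, `Cc1cccc(NC(=O)c2ccc(/N=N\c3c[nH]c4ccccc34)cc2)c1C`, gives 106000 nM in the same assay, and the step of a 1.0-fold lower number from compound 1 to compound 2 (0.02 log units; within the scatter) lies within the scatter. Compound 3, `O=C(Nc1cccc(Cl)c1)c1ccc(/N=N\c2c[nH]c3ccccc23)cc1`, is not yet measured. Its change from compound 2: 3-chlorophenyl in place of 2-nitrophenyl on an amide-type nitrogen. For the measured compounds named here, the only step that bears on it is the exchange of the aryl group on the amide-type nitrogen, which was flat, so no move beyond the scatter is expected: a 1.0-fold lower number from compound 2 to compound 3 (0.00 log units; within the scatter). Compound 3 is therefore estimated at 100000 nM, expected between 40000 nM and 250000 nM.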

Compound 3, half-maximal inhibitory concentration: 82700 nM
The estimate for compound 3 lay 1.2-fold (0.08 log units) above the measured number; low and high end bracket the measured number.
By their numbers in this assay, from the lowest: compounds 3, 2 and 1 (each within the scatter of the next).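

With 3-chlorophenyl on the amide-type nitrogen, the flat result in this assay now extends to a third aryl group and to a chlorine-bearing ring (a 1.2-fold lower number from compound 2 to compound 3 (0.09 log units; within the scatter); a 1.3-fold lower number from compound 1 to compound 3 (0.11 log units; within the scatter)). Neither the 2-nitrophenyl nor the 2,3-dimethylphenyl exchange moves the number beyond the scatter, so this position has shown no measurable response across compound 1, compound 2 and compound 3.

Open, from the compounds shown here alone, is whether any group here can move the number beyond the scatter, such as a cyclohexyl ring or a phenyl ring carrying an amine or a carboxylic acid. Nothing measured here accounts for the flat result.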